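The compounds below may be only part of what the source reports. "The series", "measured", "known", "first", "only" and "open" are said of these compounds alone.

For the measured compounds named here, in an assay on isolated protein for inhibition of sodium-dependent dopamine transporter (Rattus norvegicus), read by radioligand binding (on this read-out lower numbers stand for stronger inhibition and higher numbers for weaker inhibition), compound 2 `CC(=O)OCC[S+]([O-])CC1CN(C)CCC1c1ccc(Cl)cc1` gives 9 nM, the lower of the two numbers so far, while compound 1 `COC(=O)C[S+]([O-])CC1CN(C)CCC1c1ccc(Cl)cc1` gives 231 nM. Going by the values given here, the single measured step, a 26-fold lower number from compound 1 to compound 2 (1.41 log units; beyond the scatter), concerns the group on a saturated chain carbon bound to a sulfur and shows that this chain end moves the read-out strongly. Compound 3 `CN1CCC(c2ccc(Cl)cc2)C(C[S+]([O-])CC(=O)NO)C1` differs from compound 2 by hydroxycarbamoyl in place of acetoxymethyl on a saturated chain carbon bound to a sulfur. Compound 1 carries a different group on that same chain carbon and gave 231 nM. A step back toward that number is therefore expected, a 17-fold higher number from compound 2 to compound 3 (1.22 log units; beyond the scatter). Compound 3 is estimated at 150 nM, range 30 nM to 800 nM.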

Compound 3, inhibition constant: 55 nM
The estimate for compound 3 lay 2.7-fold (0.44 log units) above the measured number; measured number inside the range.
By their numbers in this assay, from the lowest: compound 2; then compound 3; then compound 1.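

In this assay this chain end now gives a graded series rather than a single contrast: hydroxycarbamoyl in place of acetoxymethyl gives a 6.1-fold higher number from compound 2 to compound 3 (0.79 log units; beyond the scatter) on a saturated chain carbon bound to a sulfur. Hydroxyamino in place of methoxy on a carbonyl carbon gives a 4.2-fold lower number from compound 1 to compound 3 (0.62 log units; beyond the scatter) and so shows that the number also moves when only the group on that carbonyl carbon changes. No data on hand account for either step. Open, going by these compounds, is where a carboxylic acid or a primary amide at this chain end would fall relative to compound 2 and compound 1, and how a longer chain bearing hydroxycarbamoyl would compare with compound 3.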